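Swapping chloro for methoxy on a hemolysis read-out

The compounds below may be only part of what the source reports. "The series", "measured", "known", "first", "only" and "open" are said of these compounds alone.

Of the compounds shown here, three have been measured in an ADME assay on cells (Erythrocyte, Homo sapiens) for activation, read by hemolysis, with a stated time of 30 min, tested at 10 mM; a higher number here means a stronger effect of the compound at the concentration tested, a lower number a weaker effect. Compound 1 `N=C(N)c1ccc(-c2ccc(-c3ccc(Cl)cc3)s2)s1` gives 81.7% in this assay. Compound 2 `N=C(N)c1ccc(-c2ccc(-c3cc(Cl)cc(Cl)c3)o2)o1` gives 89.3%, and compound 3 `COc1cc(-c2ccc(-c3ccc(C(=N)N)s3)s2)cc(OC)c1OC` gives 79.7%. Compound 1 stands second highest of the three numbers, with compound 3 the nearest and compound 2 the furthest, but both gaps lie within the usual scatter of repeated measurements, so the three values cannot be told apart with confidence.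

Compound 4 `COc1ccc(-c2ccc(-c3ccc(C(=N)N)s3)s2)cc1` has not yet been measured. It differs from compound 1 in one place: methoxy in place of chloro on an aromatic carbon. Among the measured compounds shown here, no pair of measured compounds isolates exactly this change, so there is no directly comparable step to lean on. Compound 3, which carries methoxy groups rather than chloro on the shared core, gives 79.7%, which shows that a core bearing methoxy can sit in the same range as compound 1. The step expected from compound 1 to compound 4 in this assay is a number 1.7 percentage points lower from compound 1 to compound 4 (within the scatter), no larger than the scatter. Compound 4 is estimated at 80%, with a range from 65% to 92%.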

Compound 4, a percentage reported as activity, at one concentration (the size of the read-out at that concentration, not a potency): 92.7%
Compound 4: the middle estimate sits 12.7 percentage points below what was measured; the whole stated range lies below it.
By their numbers in this assay, from the lowest: compounds 3, 1, 2 and 4 (each within the scatter of the next, the first and the last beyond it).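

In this assay, placing methoxy in place of chloro on the six-membered aromatic ring, para to a large group, gives a step of a number 11 percentage points higher from compound 1 to compound 4 (beyond the scatter). Among the compounds shown here, this is the first change in one place that can be read here. The step lies beyond the usual scatter of repeated measurements, with methoxy on the higher side. Nothing measured here bears on what lies behind the step.

On these data alone, whether other groups at this position, such as an amine, a hydroxyl or a longer ether like ethoxy, would give a similar number remains open. It is also unknown whether the same swap would give a step of similar size and direction on a different core.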